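This account rests on a few compounds, and the source may have more. Where it says the series, first, only, none or still open, it means among the compounds named here.

Compound 1 `Cc1nn(C)c2c1C(c1cccc(F)c1)=NCCN2` and compound 2 `Cc1cccc(C2=NCCNc3c2c(C)nn3C)c1` share one core and differ only by methyl in place of fluoro on an aromatic carbon. In a functional assay on the whole organism for positive allosteric modulation, with Rattus norvegicus as the target (a lower number here means that less compound is needed, a higher number that more compound is needed for the effect), compound 1 gives 2.5 mg/kg, and in this assay compound 2 gives 2.5 mg/kg. Among the compounds with values here, the single measured step, no change at the digits printed from compound 1 to compound 2 (within the scatter), shows that this swap left the minimum effective dose unchanged within the scatter. Compound 2 therefore stands level with compound 1 on the numbers shown, and no order can be read between them.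

Within the data shown here, compound 3 `Cc1nn(C)c2c1C(c1cccc(C#N)c1)=NCCN2` is the next member of the series. cyano in place of methyl on an aromatic carbon The only measured step that bears on this change is no change at the digits printed from compound 1 to compound 2 (within the scatter), which was flat; it concerns the same aromatic carbon but a different pair of groups, and no measured compound carries a cyano group anywhere. On that thin basis compound 3 is expected to remain close to compound 2. For compound 3 the expected step is no change at the digits printed from compound 2 to compound 3 (within the scatter), which stays within the scatter. The estimate for compound 3 in this assay is 2.5 mg/kg, with a range from 1.2 mg/kg to 5 mg/kg.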

Compound 3, minimum effective dose: 1.25 mg/kg
Estimate against measurement, compound 3: 2.0-fold (0.30 log units) above; the measured number falls inside the stated range.
By their numbers in this assay, from the lowest: compounds 3, 1 and 2 (each within the scatter of the next).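

In this assay, cyano on this aromatic carbon, meta to a large group, gives a 2.0-fold lower number from compound 2 to compound 3 (0.30 log units; within the scatter) when it takes the place of methyl and a 2.0-fold lower number from compound 1 to compound 3 (0.30 log units; within the scatter) when it takes the place of fluoro. Within the data shown here, the earlier pair covered only fluoro and methyl, whereas cyano brings two heavy atoms, a triple bond and a hydrogen-bond acceptor, and still no step among compound 1, compound 2 and compound 3 lies beyond the scatter, so at this position these three groups cannot be told apart by the minimum effective dose. Nothing at hand offers an explanation for these numbers.

The compounds shown leave open whether a group of a different kind on this carbon, such as an amine, a carboxylic acid or a longer chain, would produce a step beyond the scatter. They also leave open whether fluoro, methyl or cyano would give the same flat picture elsewhere on this six-membered aromatic ring, since all three stand at the same place.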